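Alkoxy chain extension on the benzamide series

The compounds below may be only part of what the source reports. "The series", "measured", "known", "first", "only" and "open" are said of these compounds alone.

Measured so far:
compound 1 `Cc1ccc(C(=O)NC(=N)NCCCCc2ccccc2)cc1`: 1140 nM
compound 2 `CCOc1ccc(C(=O)NC(=N)NCCCCc2ccccc2)cc1`: 760 nM

In an assay on CHO cells for inhibition of sodium channel protein type 2 subunit alpha (Homo sapiens) (on this read-out higher numbers stand for weaker inhibition and lower numbers for stronger inhibition), compound 1 gives 1140 nM and compound 2 gives 760 nM. The two numbers lie within the scatter of each other: a 1.5-fold lower number from compound 1 to compound 2 (0.18 log units; within the scatter). Compound 2 therefore has no separation from compound 1 that can be read as a real difference.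

Compound 3 `CCCCOc1ccc(C(=O)NC(=N)NCCCCc2ccccc2)cc1` is not yet measured. It differs from compound 2 by ethyl in place of hydrogen on a saturated chain carbon, two bonds along the chain from an oxygen on an aromatic ring, which extends the ethoxy group to butoxy. Within the data shown here, the only measured step that bears on this side of the core is the one from compound 1 to compound 2, ethoxy in place of methyl, and it stayed within the scatter. Nothing in the data points to a large move in either direction. The expectation for the step from compound 2 to compound 3 is therefore a 1.3-fold lower number from compound 2 to compound 3 (0.10 log units; within the scatter), at most a small change. Compound 3 is estimated at 600 nM in this assay, with a range from 250 nM to 1500 nM.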

Compound 3, half-maximal inhibitory concentration: 630 nM
Estimate against measurement, compound 3: 1.1-fold (0.02 log units) below; the measured number falls inside the stated range.
By their numbers in this assay, from the lowest: compounds 3, 2 and 1 (each within the scatter of the next).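

In this assay, extending ethoxy to butoxy gives a 1.2-fold lower number from compound 2 to compound 3 (0.08 log units; within the scatter) and so adds an ethyl on the saturated chain carbon, two bonds along the chain from an oxygen on an aromatic ring, without a difference that can be read as real. The larger replacement of methyl by butoxy on an aromatic carbon gives a 1.8-fold lower number from compound 1 to compound 3 (0.26 log units; within the scatter) and shows that even the two end members of this set of groups stay unseparated, so methyl, ethoxy and butoxy cannot be told apart at this position. No independent data are available to interpret this result.

Still open, on these data alone, is whether a longer chain such as octyloxy, or a butoxy chain ending in an amine or a carboxylic acid, would separate from compound 3. The compounds shown also leave open how changes elsewhere on the shared core would read.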